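Swapping a chloro for an iodo on a urea scaffold

A few compounds are considered here, and "the series" means these few. Any claim that something is new, unique, unknown or untested is made for them only; others in the source may bear on it.

Among the measured compounds shown here, compound 2 `C[C@@H](NC(=O)Nc1ccccc1Cl)c1ccccc1` is one of two compounds measured in an ADME assay on the whole organism with Oryza sativa as the target, tested at 10 uM; on this read-out lower numbers stand for a stronger effect and higher numbers for a weaker effect at the one concentration tested. Compound 2 gives 93%, the higher of the two numbers. For the measured compounds named here, its only neighbour is compound 1 `C[C@@H](NC(=O)Nc1ccccc1C(F)(F)F)c1ccccc1`, which gives 54%; the step of a number 39 percentage points higher from compound 1 to compound 2 (beyond the scatter) is the sole measured step so far. Compound 3 `C[C@@H](NC(=O)Nc1ccccc1I)c1ccccc1` has not been measured. It differs from compound 2 in one place: iodo in place of chloro on an aromatic carbon. Going by the values given here, the one measured step concerns a different exchange, trifluoromethyl for chloro, and so bears only loosely on an exchange of chloro for iodo; it shows that the group in this place can move the number a long way, but not which way a second halogen swap goes. A modest move downward is therefore expected, with a wide range: a number 15 percentage points lower from compound 2 to compound 3 (beyond the scatter) is the expected step, and compound 3 is estimated at 78%, between 50% and 98%.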

Compound 3, a percentage reported as activity, at one concentration (the size of the read-out at that concentration, not a potency): 96%
Estimate against measurement, compound 3: 18 percentage points below, and the stated range covers the measured number.
By their numbers in this assay, from the lowest: compound 1; then compounds 2 and 3 (each within the scatter of the next).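

In this assay the exchange of chloro for iodo gives a number 3 percentage points higher from compound 2 to compound 3 (within the scatter) and so leaves the number unchanged within the scatter, which means that these two halogens cannot be told apart at this place on the ring. The exchange of trifluoromethyl for iodo gives a number 42 percentage points higher from compound 1 to compound 3 (beyond the scatter) and is about as large as the earlier step to chloro, so two different replacements of trifluoromethyl now lead to the same high level, and compound 1 alone stands apart with the lowest number. No measurement here explains why trifluoromethyl differs from these two halogens.

The compounds shown leave open whether any group other than trifluoromethyl at this place, such as methoxy, nitrile or methyl, would also bring the number down. They also leave open whether fluoro would fall with chloro and iodo.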